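A few compounds are considered here, and "the series" means these few. Any claim that something is new, unique, unknown or untested is made for them only; others in the source may bear on it.

Measured compounds in a functional assay on SW480 cells (Homo sapiens) for cytotoxicity, read by MTT assay, with a stated time of 48 h; a higher number here means a weaker inhibitor, a lower number a stronger inhibitor:
- compound 1, `Cc1cccc(Cn2cc(COc3ccc4c(=O)ccoc4c3)nn2)c1`: 11700 nM
- compound 2, `O=c1ccoc2cc(OCc3cn(Cc4cccc(Br)c4)nn3)ccc12`: a limit of the assay, > 100000 nM
- compound 3, `O=c1ccoc2cc(OCc3cn(Cc4ccc(Cl)cc4Cl)nn3)ccc12`: a limit of the assay, > 100000 nM

Compound 3 stands at the weak end of the three values shown; its value is a limit and not a number, and the same limit holds for one further compound (the limit of > 100000 nM in this assay, at which 2 of the 3 values shown sit). Compound 4, `O=c1ccoc2cc(OCc3cn(Cc4ccc(Cl)cc4)nn3)ccc12`, is not yet measured and differs from compound 3 by hydrogen in place of chloro on an aromatic carbon.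

For the measured compounds named here, two measured steps bear on this change. The step of an at least 8.5-fold higher number from compound 1 to compound 3 (0.93 log units; beyond the scatter) and the step of an at least 8.5-fold higher number from compound 1 to compound 2 (0.93 log units; beyond the scatter) both run from a methyl-bearing benzyl to a halogen-bearing benzyl and both end at the limit. The step that the two limits leave unreadable from compound 2 to compound 3 cannot be read, because both ends are limits. Compound 4 keeps one chloro group on the benzyl ring, so it sits between compound 2 and compound 3 in the halogen count and nothing in the data points to recovery of the potency of compound 1.

In this assay the step from compound 3 to compound 4 is expected to be a number no higher from compound 3 to compound 4 (the limit leaves the size open), that is, no change beyond the scatter, and compound 4 is estimated at 100000 nM, within 30000 nM to 300000 nM, with a real chance that only a limit is reported again.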

Compound 4, half-maximal inhibitory concentration: > 100000 nM
Compound 4 gave a limit, no number; the forecaster's own chance of this, stated with the estimate: 60%; the middle value sits exactly at the limit.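

In this assay, taking the chloro group off the 2,4-dichlorobenzyl to leave the 4-chlorobenzyl does not bring back a readable value: compound 4 stays at a limit of the assay, > 100000 nM. A second chloro group is therefore not required for the loss seen on this benzyl ring, since a single chloro group already gives an at least 8.5-fold higher number from compound 1 to compound 4 (0.93 log units; beyond the scatter). All three halogen-bearing benzyl compounds now sit at the limit, with the methyl-bearing compound 1 alone going against this, and the steps among compound 2, compound 3 and compound 4 cannot be read, so the chloro group's removal has no measurable size here: the limit of > 100000 nM in this assay, at which 3 of the 4 values shown sit.

The compounds shown leave open whether the reading of compound 1 depends on the methyl group itself or merely on the absence of a halogen, and an unsubstituted benzyl, or a methoxy or amine group on the same ring, would bear on that. As far as these compounds go, how far apart the halogen-bearing compounds lie beyond the limit also stays open.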